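Piperazinylsulfonyl in place of diethylcarbamoyl on the shared core

The source may report more compounds than this note shows. Statements on the series, on what has been measured and on what is new or still open speak of the compounds shown alone.

Measured in a functional assay on MIA PaCa-2 cells (Homo sapiens) for inhibition, read by MTT assay, with a stated time of 7 days; on this read-out higher numbers stand for weaker inhibition and lower numbers for stronger inhibition:
compound 1 `CCOC(=O)[C@@H]1CCCN(S(=O)(=O)c2ccc(S(=O)(=O)N(CC)C(C)C)cc2)C1` gives 1000 nM
compound 2 `CCOC(=O)[C@@H]1CCCN(S(=O)(=O)c2ccc(S(=N)(=O)N(CC)CC)cc2)C1` gives 2600 nM
compound 3 `CCOC(=O)[C@@H]1CCCN(S(=O)(=O)c2ccc(C(=O)N(CC)CC)cc2)C1` gives 800 nM

Compound 3 has the lowest number of the three. The step of a 1.3-fold lower number from compound 1 to compound 3 (0.10 log units; within the scatter) lies within the scatter, so the two cannot be ordered; the step of a 3.3-fold lower number from compound 2 to compound 3 (0.51 log units; beyond the scatter) lies beyond it.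

Compound 4 `CCOC(=O)[C@@H]1CCCN(S(=O)(=O)c2ccc(S(=O)(=O)N3CCNCC3)cc2)C1` is the next step from compound 3: (piperazin-1-yl)sulfonyl in place of diethylcarbamoyl on an aromatic carbon.

Going by the values given here, two measured steps bear on this. The exchange of diethylcarbamoyl for ethyl(isopropyl)sulfamoyl, a 1.3-fold lower number from compound 1 to compound 3 (0.10 log units; within the scatter), shows that a sulfamoyl in place of the carbamoyl leaves the number essentially unchanged. The step of a 2.6-fold higher number from compound 1 to compound 2 (0.41 log units; beyond the scatter) shows that altering the sulfamoyl group itself moves the number only modestly. Among the compounds with values here, no measured compound carries a ring in this position, so the ring and the hydrogen-bond donor counted for compound 4 are untested.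

Taken together, a small upward shift in this assay, a 1.6-fold higher number from compound 3 to compound 4 (0.21 log units; within the scatter), is expected for compound 4, with wide uncertainty. Compound 4 is estimated at 1300 nM, between 450 nM and 4000 nM.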

Compound 4, half-maximal inhibitory concentration: > 30000 nM
Compound 4: a limit, no number (the forecaster's own chance of this, stated with the estimate: 5%); middle value at least 23-fold (1.36 log units) from the limit.
By their numbers in this assay, from the lowest: compounds 3 and 1 (each within the scatter of the next); then compound 2. At a limit, above all of these: compound 4.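

In this assay compound 4 gives > 30000 nM, which is a limit of the assay and not a number. With the sulfonyl kept, exchanging only the amine on the sulfonyl sulfur gives an at least 30-fold higher number from compound 1 to compound 4 (1.47 log units; beyond the scatter), so the sulfonyl link alone does not account for the loss, and the piperazin-1-yl group is the part that changes the read-out. The other steps point the same way, an at least 37-fold higher number from compound 3 to compound 4 (1.57 log units; beyond the scatter) and an at least 11-fold higher number from compound 2 to compound 4 (1.06 log units; beyond the scatter), all large, whereas the open-chain groups on this aromatic carbon in compounds 1, 2 and 3 stayed within a far narrower range.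

The shown compounds do not separate the ring from the ring amine hydrogen; a piperidin-1-yl, morpholin-4-yl or 4-methylpiperazin-1-yl group on the sulfonyl would address this. Going by these compounds, the true size of these steps also stays open at the limit.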